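Adding an Indole Ring: Expected Cytotoxicity of Compound 4

This account rests on a few compounds, and the source may have more. Where it says the series, first, only, none or still open, it means among the compounds named here.

Compound 1 `CC(C)N(Cc1cccc(OCCCCCC(=O)O)c1)C(=O)c1ccc(-c2cccc(Oc3ccccc3)c2)cc1` reached only the limit > 18700 nM in an ADME assay on BJ cells (Homo sapiens) for cytotoxicity, read by CellTiter-Glo and resazurin assay, with a stated time of 72 h; a lower number here means that less compound is needed, a higher number that more compound is needed for the effect. Compound 2 `CC(C)N(Cc1cccc(OCCCCCC(=O)O)c1)C(=O)c1ccc(-c2cccc(S(C)(=O)=O)c2)cc1` likewise gave only the limit > 26000 nM in this assay. Compound 3 `CCOC(=O)CCCCCOc1cccc(CN(C(=O)c2ccccc2)C(C)C)c1` also stopped at the limit > 26000 nM in this assay.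

All three measured values are limits rather than numbers, so compound 3 cannot be placed above or below the others; it simply sits at one of the two limits seen, as summarised in the limit of > 26000 nM in this assay, at which 2 of the 3 values shown sit, and (the limit of > 18700 nM in this assay, at which 1 of the 3 values shown sits). The change leading to compound 4 `CCOC(=O)CCCCCOc1cccc(CN(C(=O)c2ccc(-c3ccc4cc[nH]c4c3)cc2)C(C)C)c1` is 1H-indol-6-yl in place of hydrogen on an aromatic carbon. Among the compounds with values here, only one measured step exists, a step that the two limits leave unreadable from compound 1 to compound 2, and it concerns a different change at a different place; it gives no readable size. Within the data shown here, the data therefore offer no measured step that speaks for a change beyond the scatter in this assay when the indolyl group enters. For compound 4 the expected step is a step that the limit leaves unreadable from compound 3 to compound 4. Compound 4 is estimated to give 30000 nM, within 10000 nM to 100000 nM, most likely reported again as a limit.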

Compound 4, half-maximal effective concentration: > 26000 nM
Compound 4 ended at the assay's limit; the forecaster's own chance of this, stated with the estimate: 70%; the middle value is on the limit's open side.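

Compound 3 and compound 4 both ended at a limit rather than a number in this assay, so the step between them cannot be read. The compounds shown leave open at what concentration any of them affects these cells, and whether the 1H-indol-6-yl group changes that concentration.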